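A Dichlorophenyl Thioether Replaces Fluorophenyl on the Shared Core

A few compounds are considered here, and "the series" means these few. Any claim that something is new, unique, unknown or untested is made for them only; others in the source may bear on it.

Compound 2 `Nc1cc(N)c2nc(-c3ccccc3)c(Sc3ccc(F)cc3)nc2c1` was tested in a functional assay on MDA-MB-435 cells (Homo sapiens) for inhibition, read by sulforhodamine B assay, with a stated time of 48 h (on this read-out lower numbers stand for stronger inhibition of growth and higher numbers for weaker inhibition of growth), where compound 2 gives 33100 nM. Among the three measured compounds it holds the second highest number. Compound 1 `CCOC(=O)[C@H](CCC(=O)O)NC(=O)c1ccc(Sc2nc3cc(N)cc(N)c3nc2-c2ccccc2)cc1` gives 33900 nM in this assay, a number that lies within the scatter of compound 2, so the two cannot be ordered. Compound 3 `COc1cc(CNc2nc3cc(N)cc(N)c3nc2-c2ccccc2)cc(OC)c1OC` gives 912 nM in this assay, a number far below that of compound 2 and beyond the scatter. For the measured compounds named here, no step between measured compounds that differ in a single place is available, so compound 3 is not tied to compound 2 by one change.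

Compound 4 `Nc1cc(N)c2nc(-c3ccccc3)c(Sc3ccc(Cl)c(Cl)c3)nc2c1` has not yet been measured. It differs from compound 2 in one place: 3,4-dichlorophenyl in place of 4-fluorophenyl on a sulfur. The sulfur carrying the aryl group keeps its other neighbour, an aromatic carbon.

Going by the values given here, with no comparable step on record, the expectation rests on compound 1, which gives 33900 nM, and on compound 2, which gives 33100 nM in this assay: both carry an arylsulfanyl group on the shared core and both sit near the same number. The estimated step of a 1.7-fold lower number from compound 2 to compound 4 (0.22 log units; within the scatter) is expected to be small, tending toward a lower number but probably not beyond the scatter. Compound 4 is therefore expected to give 20000 nM, with a range from 5000 nM to 60000 nM.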

Compound 4, concentration for total growth inhibition: 60300 nM
Estimate against measurement, compound 4: 3.0-fold (0.48 log units) below; the whole stated range lies below it.
By their numbers in this assay, from the lowest: compound 3; then compounds 2, 1 and 4 (each within the scatter of the next).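

For the compounds shown here, exchanging 4-fluorophenyl for 3,4-dichlorophenyl on a sulfur gives the first step on the shared core that can be read as a single change: in this assay it amounts to a 1.8-fold higher number from compound 2 to compound 4 (0.26 log units; within the scatter) and so does not separate the two compounds. Within this one pair, the read-out therefore gives no sign that the choice between these two aryl groups on the sulfur matters, although a single pair cannot show how the position responds to aryl groups in general. No measurement is at hand that could account for this outcome or tie it to any property of either group.

As far as these compounds go, it remains open whether a simple phenyl, or a phenyl carrying an amine or a carboxylic acid, would shift the number beyond the scatter from that of compound 2 in this assay. It is equally open what the sulfur itself contributes, since the compounds shown do not reveal what an amine nitrogen in its place would do with the 4-fluorophenyl group and the rest of compound 2 kept unchanged.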